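From hydroxy to acetoxy on compound 1

This account rests on a few compounds, and the source may have more. Where it says the series, first, only, none or still open, it means among the compounds named here.

- compound 1 `CC1=CC[C@H]2[C@@H]1CC=C(C)[C@@H](CC[C@H]1[C@]3(C)CC[C@H](O)C(C)(C)O[C@H]3CC[C@@]1(C)O)C2(C)C`: > 50000 nM
- compound 2 `CC(=O)O[C@H]1CC[C@]2(C)[C@H](CC[C@@](C)(O)[C@H]2CC[C@@H]2C(C)=CC[C@H]3[C@H](CC[C@]3(C)O)C2(C)C)OC1(C)C`: 38000 nM
- compound 3 `CC1=CC[C@H]2[C@H](CC[C@]2(C)O)C(C)(C)[C@@H]1CC[C@H]1[C@]2(C)CC[C@H](OC(=O)c3ccncc3)C(C)(C)O[C@H]2CC[C@@]1(C)O`: 18000 nM

All three values come from a functional assay on MDA-MB-231 cells (Homo sapiens) for antiproliferative activity, read by MTT assay, with a stated time of 72 h; on this read-out lower numbers stand for stronger inhibition and higher numbers for weaker inhibition. In this assay compound 1 stands at > 50000 nM, which is a limit of the assay and not a number; this is the limit of > 50000 nM in this assay, at which 1 of the 3 values shown sits. Its true value is therefore unknown.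

The next compound is compound 4 `CC(=O)O[C@H]1CC[C@]2(C)[C@H](CC[C@@](C)(O)[C@H]2CC[C@@H]2C(C)=CC[C@@H]3C(C)=CC[C@@H]3C2(C)C)OC1(C)C`, which has not yet been measured. It differs from compound 1 by one change: acetyl in place of hydrogen on an oxygen on a saturated carbon. Put simply, a hydroxy group becomes an acetoxy group.

Within the data shown here, no measured step makes this exact change. The closest is a 2.1-fold lower number from compound 2 to compound 3 (0.32 log units; beyond the scatter), where pyridin-4-yl takes the place of methyl on a carbonyl carbon. That step is modest, and it swaps one group on the carbonyl for another instead of adding an acetyl group, so it is only an indirect guide. Compound 2, which carries the acetyl group, gives 38000 nM in this assay.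

A small move towards a lower number is therefore expected, and compound 4 may well remain at the limit. The expected change is an at least 1.2-fold lower number from compound 1 to compound 4 (0.09 log units; that floor lies within the scatter). Compound 4 is estimated at 40000 nM, with an expected range of 20000 nM to 80000 nM.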

Compound 4, half-maximal inhibitory concentration: 39200 nM
Compound 4: the middle estimate sits 1.0-fold (0.01 log units) above what was measured, within the range that was stated.
By their numbers in this assay, from the lowest: compound 3; then compounds 2 and 4 (each within the scatter of the next). At a limit, above all of these: compound 1.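

In this assay, the change from hydroxy to acetoxy on this oxygen on a saturated carbon now has a direct reading of its own: an at least 1.2-fold lower number from compound 1 to compound 4 (0.10 log units; that floor lies within the scatter). The acetyl group gives a measurable number on the core of compound 1, with compound 4 at 39200 nM. The size of the change remains uncertain. Compound 1 itself stands at a value that is a limit of the assay and not a number: the limit of > 50000 nM in this assay, at which 1 of the 4 values shown sits.

The compounds shown leave open how far the number would move with other groups on this carbonyl, such as a longer chain like hexanoyl or a carbonyl bearing an amine, which would show whether the gain seen with pyridin-4-yl extends beyond that one ring. They also leave open whether a carbonyl is needed on this oxygen at all, a question that a simple methyl ether in place of the acetyl group would address.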